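Carbamoylmethyl in place of isopropyl on an amine nitrogen

The source may hold more compounds than are shown below. What is called first, only, known or untested is meant among the compounds shown, and "the series" means these compounds.

Compound 1 `CC(C)=CCc1cc(C(=O)Nc2cc3ccc(OCC4CCCN(C)C4)c(C)c3oc2=O)ccc1O`: 1300 nM
Compound 2 `CC(C)=CCc1cc(C(=O)Nc2cc3ccc(OCC4CCCNC4)c(C)c3oc2=O)ccc1O`: 600 nM
Compound 3 `CC(C)=CCc1cc(C(=O)Nc2cc3ccc(OCCCNC(C)C)c(C)c3oc2=O)ccc1O`: 750 nM

All three compounds were tested in a functional assay on SK-BR-3 cells (Homo sapiens) for antiproliferative activity; on this read-out lower numbers stand for stronger inhibition and higher numbers for weaker inhibition. Compound 3 gives 750 nM, which lies within the scatter of both other values: the data show a 1.3-fold higher number from compound 2 to compound 3 (0.10 log units; within the scatter) and a 1.7-fold lower number from compound 1 to compound 3 (0.24 log units; within the scatter).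

Compound 4 `CC(C)=CCc1cc(C(=O)Nc2cc3ccc(OCCCNCC(N)=O)c(C)c3oc2=O)ccc1O` has not yet been measured. It keeps everything in compound 3 except one group, with carbamoylmethyl in place of isopropyl on an amine nitrogen.

Among the compounds with values here, no measured compound carries carbamoylmethyl, so the earlier steps offer only indirect guidance. They do show how far changes around this amine have moved the number in this assay. The largest is a 2.2-fold lower number from compound 1 to compound 2 (0.34 log units; beyond the scatter), a modest step, and the other two stay within the scatter. A similarly small change is therefore expected here, probably within the scatter, with a slight lean towards a higher number, which would mean weaker inhibition. That lean is a judgement only, as the data contain no direct comparison for this group. The expected step is a 1.2-fold higher number from compound 3 to compound 4 (0.08 log units; within the scatter). For compound 4 the estimated value is 900 nM, with an expected range from 300 nM to 2700 nM.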

Compound 4, half-maximal inhibitory concentration: 2290 nM
Compound 4: the middle estimate sits 2.5-fold (0.41 log units) below what was measured, within the range that was stated.
By their numbers in this assay, from the lowest: compounds 2, 3, 1 and 4 (each within the scatter of the next, the first and the last beyond it).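

In this assay, the group on this amine nitrogen matters more than the earlier changes to the chain suggested: a 3.1-fold higher number from compound 3 to compound 4 (0.48 log units; beyond the scatter), beyond the scatter, whereas swapping the piperidine-bearing side chains for the isopropylamino chain had stayed within it. Compound 4 also gives the largest step in the set, a 3.8-fold higher number from compound 2 to compound 4 (0.58 log units; beyond the scatter), yet it cannot be separated from the methylated ring compound, with a 1.8-fold higher number from compound 1 to compound 4 (0.25 log units; within the scatter), so carbamoylmethyl weakens inhibition clearly relative to isopropyl but does not take the series beyond the range already spanned by compound 1. The swap replaces a group with no hydrogen-bond donors or acceptors by one carrying one of each and adds a heavy atom, but nothing available explains why the number goes up.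

A carboxylic acid, a hydroxyethyl group or a plain ethyl group on the same nitrogen would help show whether the primary amide itself drives the step or whether losing isopropyl is enough. Carbamoylmethyl on the ring nitrogen of compound 2 would test whether the same swap carries over to the piperidine series.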